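Fluoro in Place of Bromo: Estimating Compound 3

The compounds below may be only part of what the source reports. "The series", "measured", "known", "first", "only" and "open" are said of these compounds alone.

Going by the values given here, compound 1 `COc1cc(OC)c(C(=O)c2ccccc2Br)c(O)c1CN1CCCCC1` gives 22% in a functional assay on THP-1 cells (Homo sapiens) for inhibition, read by ELISA, with stated times of 30 min and 24 h, tested at 1 uM (on this read-out lower numbers stand for a weaker effect and higher numbers for a stronger effect at the one concentration tested), the highest of the two numbers measured so far. Compound 2 `COc1cc(O)c(C(=O)c2ccccc2Br)c(OC)c1` gives 7% in this assay; the step of a number 15 percentage points lower from compound 1 to compound 2 (beyond the scatter) came with hydrogen in place of (piperidin-1-yl)methyl on an aromatic carbon. Compound 3 `COc1cc(OC)c(C(=O)c2ccccc2F)c(O)c1CN1CCCCC1` differs from compound 1 by fluoro in place of bromo on an aromatic carbon. Among the compounds with values here, no measured step exchanges one halogen for another, so the single known step touches a different part of the molecule and does not bear on this change. The expected step is therefore small, a number 4 percentage points lower from compound 1 to compound 3 (within the scatter), within the scatter. Compound 3 is estimated at 18%, with a range from 4% to 35%.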

Compound 3, a percentage reported as activity, at one concentration (the size of the read-out at that concentration, not a potency): 18%
The estimate for compound 3 equals the measured number at the digits printed; the measured number falls inside the stated range.
By their numbers in this assay, from the lowest: compound 2; then compounds 3 and 1 (each within the scatter of the next).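

In this assay the step of a number 4 percentage points lower from compound 1 to compound 3 (within the scatter) shows that bromo on the 2-bromophenyl group can give way to fluoro with no difference beyond the scatter. Going by these compounds alone, the earlier step concerned only the (piperidin-1-yl)methyl group, so this is the first reading on the halogen itself, and it rests on this single pair. Nothing measured here speaks to the reason for this result.

Open, from the compounds shown here alone, is how this position would respond to a group other than a halogen, such as methoxy, an amine or a carboxylic acid. Also open, going by these compounds, is whether chloro or plain hydrogen there would read like bromo and fluoro.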